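A chain change among compounds stuck at a limit

The source may hold more compounds than are shown below. What is called first, only, known or untested is meant among the compounds shown, and "the series" means these compounds.

In a physicochemical assay for solubility, in phosphate buffer, at pH 6.8 (a higher number here means a more soluble compound, a lower number a less soluble compound), compound 3 (`CC(C)C(=O)C1=C(O)C(=O)N(c2ccc(-c3ccsc3)cc2)C1c1ccccc1OCCO`) reads > 50000 nM, which is a limit of the assay and not a number. Compound 2 (`COc1ccccc1C1C(C(=O)C(C)C)=C(O)C(=O)N1c1ccc(-c2ccsc2)cc1`) also gives only a limit, > 50000 nM. Compound 1 (`C[S+]([O-])CCOc1ccccc1C1C(C(=O)C(C)(C)C)=C(O)C(=O)N1c1ccc(-c2ccsc2)cc1`) gives a limit as well, > 50000 nM. Taken together, the evidence is the limit of > 50000 nM in this assay, at which 3 of the 3 values shown sit.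

Compound 4 (`CC(C)C(=O)C1=C(O)C(=O)N(c2ccc(-c3ccsc3)cc2)C1c1ccccc1OCC[S+](C)[O-]`) has not yet been measured. It replaces the hydroxy of compound 3 with a group that has no common name, on a saturated chain carbon, two bonds along the chain from an oxygen on an aromatic ring: a group of 3 heavy atoms (1 carbon, 1 oxygen, 1 sulfur; no ring) in place of one oxygen atom, on a saturated chain carbon, two bonds along the chain from an oxygen on an aromatic ring.

Going by the values given here, the one measured step that bears on this change is a step that the two limits leave unreadable from compound 2 to compound 3, so it offers no size to carry over. Expected here is a step that the limit leaves unreadable from compound 3 to compound 4, a change within the usual scatter with no favoured direction, and this assay may well report only a limit again. For compound 4 the estimated solubility is 60000 nM, with an expected range of 40000 nM to 100000 nM.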

Compound 4, solubility: > 50000 nM
Compound 4 ended at the assay's limit; the forecaster's own chance of this, stated with the estimate: 85%; the middle value does not contradict the limit.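

In this assay compound 4 gives > 50000 nM, which is a limit and not a number. Compound 1, compound 2 and compound 3 also sit at limits, so no step among these four can be read. Their true solubilities, and any order among them, stay open: the limit of > 50000 nM in this assay, at which 4 of the 4 values shown sit.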